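The source may report more compounds than this note shows. Statements on the series, on what has been measured and on what is new or still open speak of the compounds shown alone.

Of the compounds shown here, two have so far been measured in an assay on membranes from brain for displacement of a labelled ligand from Neuronal acetylcholine receptor; alpha4/beta2 (Rattus norvegicus); on this read-out lower numbers stand for stronger inhibition and higher numbers for weaker inhibition. Compound 1 `CN1CCC[C@H]1COc1cccnc1[N+](=O)[O-]` gives 9000 nM there, while compound 2 `Cc1cncc(OC[C@@H]2CCCN2C)c1` gives 0.48 nM, the lowest of the two numbers and far beyond the usual scatter from compound 1. These two compounds differ at more than one place, so their gap cannot be traced to a single change. Compound 3 `CCNc1cncc(OC[C@@H]2CCCN2C)c1` has not yet been measured. Compared with compound 2 it carries ethylamino in place of methyl on an aromatic carbon. Among the measured compounds shown here, no step between two measured compounds shows the effect of this kind of change, so the expectation rests only on how strong compound 2 is at 0.48 nM. A modest weakening is expected, as the step of a 6.3-fold higher number from compound 2 to compound 3 (0.80 log units; beyond the scatter), which would still leave compound 3 far stronger than compound 1. Compound 3 is therefore estimated at 3 nM, within a range from 0.5 nM to 20 nM.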

Compound 3, inhibition constant: 3.7 nM
Compound 3: middle estimate off by 1.2-fold (0.09 log units), on the low side, within the range that was stated.
By their numbers in this assay, from the lowest: compound 2; then compound 3; then compound 1.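

Among the compounds shown here, replacing methyl with ethylamino on this aromatic carbon, two atoms from the ring nitrogen, gives a 7.7-fold higher number from compound 2 to compound 3 (0.89 log units; beyond the scatter) in this assay and is the first change at a single place whose size can be read. The position therefore accepts a group with more heavy atoms, plus a hydrogen-bond donor and acceptor, at a modest cost, since compound 3 still gives 3.7 nM on this read-out. Nothing available explains why the number rises.

This single step brings in a nitrogen and a longer chain together, so it leaves open which of the two goes with the weaker binding. Compounds carrying a plain ethyl group, an unsubstituted amino group or a propylamino group at this place would pull those two apart.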